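The source may hold more compounds than are shown below. What is called first, only, known or untested is meant among the compounds shown, and "the series" means these compounds.

Compound 1 `CN1CCC(C(=O)N2Cc3c(NC(=O)C4CC4)n[nH]c3C2(C)C)CC1` carries a cyclopropyl on the carbonyl carbon of its amide, and in a functional assay on A2780 cells (Homo sapiens) for antiproliferative activity, read by fluorescence, with a stated time of 72 h (on this read-out higher numbers stand for weaker inhibition and lower numbers for stronger inhibition), compound 1 gives 1420 nM, the highest number among the three compounds measured. Two changes at that carbonyl carbon have already been recorded. Compound 2 `CN1CCC(C(=O)N2Cc3c(NC(=O)c4ccsc4)n[nH]c3C2(C)C)CC1` gives 140 nM in this assay, and the step of a 10-fold lower number from compound 1 to compound 2 (1.01 log units; beyond the scatter) is the largest so far. Compound 3 `CN1CCC(C(=O)N2Cc3c(NC(=O)Nc4cccc(F)c4)n[nH]c3C2(C)C)CC1` gives 350 nM in this assay; the step of a 4.1-fold lower number from compound 1 to compound 3 (0.61 log units; beyond the scatter) is smaller, and the step of a 2.5-fold higher number from compound 2 to compound 3 (0.40 log units; beyond the scatter) places compound 2 ahead of compound 3. Compound 4 `CN1CCC(C(=O)N2Cc3c(NC(=O)c4ccc(C(F)(F)F)cc4)n[nH]c3C2(C)C)CC1` has not yet been measured. It differs from compound 1 by 4-(trifluoromethyl)phenyl in place of cyclopropyl on a carbonyl carbon. Both recorded steps bear on this change, since each puts an aromatic group on the same carbonyl carbon in place of cyclopropyl and each lowered the number beyond the scatter; the direct aromatic amide of compound 2 is the closer precedent because of a 10-fold lower number from compound 1 to compound 2 (1.01 log units; beyond the scatter). A lower number for compound 4 is therefore expected, of a size between the two recorded steps, which means an expected step of a 6.5-fold lower number from compound 1 to compound 4 (0.81 log units; beyond the scatter). The estimate for compound 4 in this assay is 220 nM, with a range from 70 nM to 700 nM.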

Compound 4, half-maximal inhibitory concentration: 60 nM
Beside the measured number, compound 4's estimate is 3.7-fold (0.56 log units) above it; measured number below the stated range.
By their numbers in this assay, from the lowest: compound 4; then compound 2; then compound 3; then compound 1.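

In this assay, within the data shown here, this carbonyl carbon proves able to carry a much larger gain than the earlier compounds showed: 4-(trifluoromethyl)phenyl in place of cyclopropyl gives a 24-fold lower number from compound 1 to compound 4 (1.37 log units; beyond the scatter) and exceeds every step recorded before it. The new group also outdoes both earlier replacements, with a 2.3-fold lower number from compound 2 to compound 4 (0.37 log units; beyond the scatter) against thiophen-3-yl and a 5.8-fold lower number from compound 3 to compound 4 (0.77 log units; beyond the scatter) against (3-fluorophenyl)amino, and among these four compounds the two aromatic rings set directly on the carbonyl carbon now hold the two lowest numbers. Nothing measured here accounts for this order, and the result stands as a ranking without an explanation.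

As far as these compounds go, what a plain phenyl ring would give on this carbonyl carbon remains open, and with it how much of the step belongs to the trifluoromethyl group and how much to the six-membered aromatic ring that carries it. Also open, from the compounds shown here alone, is how a 3-(trifluoromethyl)phenyl group, or a phenyl ring bearing an amine or a carboxylic acid, would fare at the same place.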